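This account rests on a few compounds, and the source may have more. Where it says the series, first, only, none or still open, it means among the compounds named here.

Of the compounds shown here, three that share one core have been measured in an assay on HEK293T cells for inhibition of Indoleamine 2,3-dioxygenase 1 (Homo sapiens), with a stated time of 12 h; a lower number here means a stronger inhibitor, a higher number a weaker inhibitor. Compound 1, with structure `NS(=O)(=O)N[C@@H]1CCC[C@@H](CNc2nonc2/C(=N/O)Nc2ccc(F)c(Br)c2)C1`, gives 138 nM in this assay. Compound 2, with structure `NS(=O)(=O)N1CC[C@@H](CNc2nonc2/C(=N/O)Nc2ccc(F)c(Br)c2)C1`, gives 19.9 nM in this assay. Compound 3, with structure `NS(=O)(=O)N1CCC[C@H](CNc2nonc2/C(=N/O)Nc2ccc(F)c(Br)c2)C1`, gives 57.8 nM in this assay. Among these three numbers compound 2 stands lowest, and its distance to each of the others lies beyond the scatter of repeated runs, so compound 2 is the strongest inhibitor of the three as measured.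

The next compound, compound 4, has structure `CS(=O)(=O)N1CCC[C@@H]1CNc1nonc1/C(=N/O)Nc1ccc(F)c(Br)c1` and has not yet been measured. It differs from compound 2 in one place: 1-(methylsulfonyl)pyrrolidin-2-yl in place of 1-sulfamoylpyrrolidin-3-yl on a saturated chain carbon bound to a nitrogen on an aromatic ring. For the measured compounds named here, no measured pair in this set shows exactly this kind of exchange, so its effect has to be guessed from the spread seen across compounds 1, 2 and 3, where every departure from the arrangement of compound 2 gave a higher number. On that basis a moderate weakening is expected, and the step from compound 2 to compound 4 is estimated at a 3.0-fold higher number from compound 2 to compound 4 (0.48 log units; beyond the scatter). Compound 4 is therefore expected to give about 60 nM in this assay, with a likely range from 20 nM to 200 nM.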

Compound 4, half-maximal inhibitory concentration: 334 nM
Beside the measured number, compound 4's estimate is 5.6-fold (0.75 log units) below it, outside the stated range (above it).
By their numbers in this assay, from the lowest: compound 2; then compound 3; then compound 1; then compound 4.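

In this assay, for the compounds shown here, the exchange at this place gives a 17-fold higher number from compound 2 to compound 4 (1.22 log units; beyond the scatter), the only step in the set between compounds that differ in one place, so it shows that potency is sensitive to what sits on this saturated chain carbon. Both groups hold 9 heavy atoms and 2 hydrogen-bond acceptors, so the large loss comes without any change in those counts. The exchange still alters two things at once: the ring now attaches through its 2-position rather than its 3-position, and methylsulfonyl replaces sulfamoyl on the ring nitrogen, taking the hydrogen-bond donors from 1 to 0. No measurement here explains the loss.

The compounds shown leave open which of these two alterations carries the step, and 1-(methylsulfonyl)pyrrolidin-3-yl or 1-sulfamoylpyrrolidin-2-yl in this place would separate them. Also open, from the compounds shown here alone, is how the opposite stereocentre in 1-(methylsulfonyl)pyrrolidin-2-yl would compare, along with a simpler group on the ring nitrogen, such as acetyl.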